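The source may report more compounds than this note shows. Statements on the series, on what has been measured and on what is new or still open speak of the compounds shown alone.

Compound 2 `COc1ccc(S(=O)(=O)/C=C/c2ncccc2F)cc1` carries a fluoro group on the shared core of compound 1 `COc1ccc(S(=O)(=O)/C=C/c2ccccn2)cc1`. In an ADME assay on BV-2 cells (Mus musculus) for cytotoxicity, with a stated time of 24 h, tested at 10 uM (a higher number here means a weaker effect of the compound at the concentration tested, a lower number a stronger effect), compound 1 gives 100%, and compound 2 gives 94.2%. Compound 2 thus stands at the lower of the two numbers shown, yet the step of a number 5.8 percentage points lower from compound 1 to compound 2 (within the scatter) is within the scatter, so the two compounds cannot be told apart in this assay. Compound 3 `COc1ccc(S(=O)(=O)/C=C/c2ncccc2Cl)cc1` has not yet been measured in this assay. It differs from compound 2 in one place: chloro in place of fluoro on an aromatic carbon. Among the compounds with values here, the only step measured so far, a number 5.8 percentage points lower from compound 1 to compound 2 (within the scatter), bears on it loosely, since it concerned fluoro in place of hydrogen on an aromatic carbon, and it stayed within the scatter. No step beyond the scatter is expected in this assay for compound 3. Compound 3 is therefore estimated at 93%, within the range 80% to 102%, an expected step of a number 1.2 percentage points lower from compound 2 to compound 3 (within the scatter).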

Compound 3, a percentage reported as activity, at one concentration (the size of the read-out at that concentration, not a potency): 94.7%
Beside the measured number, compound 3's estimate is 1.7 percentage points below it, and the stated range covers the measured number.
By their numbers in this assay, from the lowest: compounds 2, 3 and 1 (each within the scatter of the next).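

In this assay the exchange of one halogen for another, on an aromatic carbon ortho to a large group and two atoms from the ring nitrogen, gives a number 0.5 percentage points higher from compound 2 to compound 3 (within the scatter) and so does not separate fluoro from chloro at this position. Chloro in place of hydrogen at the same place gives a number 5.3 percentage points lower from compound 1 to compound 3 (within the scatter) and so shows that a second halogen, not fluoro alone, also stays indistinguishable from compound 1 with its hydrogen. No measurement at hand explains why these numbers stay so close. Still open, as far as these compounds go, is whether a group of another kind at this position, such as an amine, a carboxylic acid or a longer chain, would give a step beyond the scatter. Also open, from the compounds shown here alone, is how these three compounds behave at other concentrations.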